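The compounds below may be only part of what the source reports. "The series", "measured", "known", "first", "only" and "open" are said of these compounds alone.

Three compounds built on a shared core have been run in an ADME assay on a cell-free system (plasma, Rattus norvegicus) for protein binding. Compound 1 `Nc1nccc(N2CC[C@H](NC(=O)Nc3ccc(Cl)c(C(F)(F)F)c3)C2)n1` gives 99.4% in this assay, compound 2 `CNc1nccc(N2CC[C@H](NC(=O)Nc3ccc(C)c(Cl)c3)C2)n1` gives 98.9%, and compound 3 `CNc1nccc(N2CC[C@H](NC(=O)Nc3ccc(CN4CCCC4)c(C(F)(F)F)c3)C2)n1` gives 87.8%. Of the three unbound fractions, compound 2 holds the second highest; its gap to compound 1 lies within the usual scatter, while compound 3 sits far beyond it with a much higher unbound fraction. Compound 4 `CNc1nccc(N2CC[C@H](NC(=O)Nc3cccc(OC)c3)C2)n1` has not yet been measured. It differs from compound 2 in one place: 3-methoxyphenyl in place of 3-chloro-4-methylphenyl on an amide-type nitrogen. For the measured compounds named here, with no closely matching pair already measured, only a modest step towards more free compound is expected, a 3.6-fold higher unbound fraction from compound 2 to compound 4 (0.56 log units; beyond the scatter). Compound 4 is accordingly expected to give 96%, in a range from 92% to 98.5%.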

Compound 4, plasma protein binding: 93.9%
The estimate for compound 4 lay 1.5-fold (0.18 log units) (unbound fraction) below the measured number; measured number inside the range.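

In this assay, for the compounds shown here, 3-methoxyphenyl in place of 3-chloro-4-methylphenyl on the amide-type nitrogen gives a 5.5-fold higher unbound fraction from compound 2 to compound 4 (0.74 log units; beyond the scatter), the first one-place step at this position and one beyond the scatter. The heavy-atom count stays the same, while chlorine leaves and one hydrogen-bond acceptor enters. Nothing available here accounts for this step. The compounds shown leave open how much of the step follows from losing the chlorine, the methyl or both, or from adding the methoxy group. Also open, going by these compounds, is how a carboxylic acid on this phenyl ring would behave.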